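Replacing the dimethylamino-bearing ring in the aryl-substituted thioxopyrimidine series

The compounds below may be only part of what the source reports. "The series", "measured", "known", "first", "only" and "open" are said of these compounds alone.

Of the compounds shown here, three with a shared core have been measured in a functional assay, with a stated time of 20 min, tested at 10 uM; a lower number here means a weaker effect, a higher number a stronger effect of the compound at the concentration tested. Compound 1 `COc1cc(/C=C/C(=O)C2=C(/C=C/c3ccc(O)c(OC)c3)NC(=S)NC2c2ccccc2)ccc1O` gives 22%. Compound 2 `COc1cc(/C=C/C(=O)C2=C(/C=C/c3ccc(O)c(OC)c3)NC(=S)NC2c2ccc(C)cc2)ccc1O` gives 19.9%; the step of a number 2.1 percentage points lower from compound 1 to compound 2 (within the scatter) shows that methyl in place of hydrogen on the aromatic carbon leaves the read-out essentially unchanged. Compound 3 `COc1cc(/C=C/C(=O)C2=C(/C=C/c3ccc(O)c(OC)c3)NC(=S)NC2c2ccc(N(C)C)cc2)ccc1O` gives 59%, the highest of the three numbers, set apart from both others, as a number 37 percentage points higher from compound 1 to compound 3 (beyond the scatter) and a number 39.1 percentage points higher from compound 2 to compound 3 (beyond the scatter) show.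

Compound 4 `COc1cc(/C=C/C(=O)C2=C(/C=C/c3ccc(O)c(OC)c3)NC(=S)NC2c2c(Cl)cccc2Cl)ccc1O` is the next compound. Its structure differs from compound 3 by 2,6-dichlorophenyl in place of 4-(dimethylamino)phenyl on a saturated ring carbon. The two steps that bear on this change run the other way: both times the dimethylamino group entered, the activity in this assay rose by a large amount, and both compounds without it, compound 1 and compound 2, sit close together at the lower level. Compound 4 also lacks that group, so the expected step of a number 34 percentage points lower from compound 3 to compound 4 (beyond the scatter) is a large fall back toward that lower level. Compound 4 is accordingly estimated at 25%, with a range from 10% to 45%.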

Compound 4, a percentage reported as activity, at one concentration (the size of the read-out at that concentration, not a potency): 20.2%
Compound 4: middle estimate off by 4.8 percentage points, on the high side; measured number inside the range.
By their numbers in this assay, from the lowest: compounds 2, 4 and 1 (each within the scatter of the next); then compound 3.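

In this assay, this saturated ring carbon proves sensitive to a change of the whole aryl group, with a large fall when 2,6-dichlorophenyl replaces 4-(dimethylamino)phenyl (a number 38.8 percentage points lower from compound 3 to compound 4 (beyond the scatter)). The same group cannot be told apart from 4-methylphenyl (a number 0.3 percentage points higher from compound 2 to compound 4 (within the scatter)) or from phenyl (a number 1.8 percentage points lower from compound 1 to compound 4 (within the scatter)), so a chlorine-bearing ring now joins the two earlier rings at the lower level, and compound 3 alone stands above them. Nothing available explains why these rings give such similar read-outs or why compound 3 differs.

The compounds shown leave open whether the higher read-out of compound 3 depends on the full dimethylamino group, or whether a plain amine or a methoxy group on the same ring would also give it. They also leave open what a single chlorine on the ring would do.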